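Dimethylmorpholine amide replacement on two cores

The source may hold more compounds than are shown below. What is called first, only, known or untested is meant among the compounds shown, and "the series" means these compounds.

The series holds compound 1 `CC(NC(=O)c1ccc(-c2ccc(NC(=O)Nc3cc(C(F)(F)F)ccc3Cl)cc2)cc1)c1ccccc1`, compound 2 `C/C(=C\C(=O)N1CC(C)OC(C)C1)c1ccc(NC(=O)Nc2ccc(Cl)c(C(F)(F)F)c2)cc1`, compound 3 `C/C(=C\C(=O)NC(C)c1ccccc1)c1ccc(NC(=O)Nc2ccc(Cl)c(C(F)(F)F)c2)cc1` and the unmeasured compound 4 `CC1CN(C(=O)c2ccc(-c3ccc(NC(=O)Nc4cc(C(F)(F)F)ccc4Cl)cc3)cc2)CC(C)O1`. In a functional assay on A-375 cells (Homo sapiens) for inhibition, read by MTT assay, with a stated time of 120 h (on this read-out higher numbers stand for weaker inhibition and lower numbers for stronger inhibition), compound 1 gives 16900 nM, a lower number than compound 2 at 46200 nM. Compound 3 reaches only > 50000 nM, which is a limit of the assay and not a number (the limit of > 50000 nM in this assay, at which 1 of the 3 values shown sits). The change 2,6-dimethylmorpholin-4-yl in place of (1-phenylethyl)amino on a carbonyl carbon produced an at least 1.0-fold lower number from compound 3 to compound 2 (0.03 log units; that floor lies within the scatter), so only a floor is known for it. The difference between the core of compound 1 and that of compound 3 is not broken down here. Compound 4 carries the same kind of change, (2,6-dimethylmorpholin-4-yl in place of (1-phenylethyl)amino on a carbonyl carbon), the carbonyl carbon now neighbouring an aromatic carbon instead of a double-bonded chain carbon. For compound 4 the expected step is a 1.1-fold lower number from compound 1 to compound 4 (0.05 log units; within the scatter), because the floor an at least 1.0-fold lower number from compound 3 to compound 2 (0.03 log units; that floor lies within the scatter) lies within the scatter and gives no direction. The estimate for compound 4 in this assay is 15000 nM, between 5000 nM and 45000 nM.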

Compound 4, half-maximal inhibitory concentration: > 50000 nM
Compound 4 was reported as a limit; the forecaster's own chance of this, stated with the estimate: 15%; middle value at least 3.3-fold (0.52 log units) from the limit.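

On the core of compound 1, 2,6-dimethylmorpholin-4-yl in place of (1-phenylethyl)amino on a carbonyl carbon gives an at least 2.9-fold higher number from compound 1 to compound 4 (0.47 log units; beyond the scatter) in this assay. The change therefore does not behave as one transferable step across the two cores: the same change on two cores in this assay, an at least 1.0-fold lower number (0.03 log units; that floor lies within the scatter) from compound 3 to compound 2 and an at least 2.9-fold higher number (0.47 log units; beyond the scatter) from compound 1 to compound 4, at least 3.2-fold (0.50 log units) apart, beyond the scatter of two such steps Both steps are only bounds, so neither the true size of the gap nor its origin can be read, with compound 3 and compound 4 each reported as a limit and not a number: the limit of > 50000 nM in this assay, at which 2 of the 4 values shown sit.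

Open, on these data alone, is which part of the 2,6-dimethylmorpholin-4-yl group goes with the result on the core of compound 1. A plain morpholin-4-yl or piperidin-1-yl amide on both cores could separate the ring oxygen and the methyl groups.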